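This account rests on a few compounds, and the source may have more. Where it says the series, first, only, none or still open, it means among the compounds named here.

Compound 1, `Cc1cc(-c2noc([C@H](C)NC(=O)c3cc(C(F)(F)F)nn3C)n2)ccn1`: 165 nM in an assay on T-REx-293 cells for inhibition of potassium channel subfamily T member 1 (Homo sapiens), read by patch clamp; on this read-out lower numbers stand for stronger inhibition and higher numbers for weaker inhibition.
Compound 2, `C[C@H](NC(=O)c1cc(C(F)(F)F)nn1C)c1nc(-c2ccncc2)no1`: 5250 nM in this assay.
Compound 3, `COc1cc(-c2noc([C@H](C)NC(=O)c3cc(C(F)(F)F)nn3C)n2)ccn1`: 27 nM in this assay.

Among these three, compound 3 stands lowest in this assay, with its nearest neighbour compound 1 (a 6.1-fold lower number from compound 1 to compound 3 (0.79 log units; beyond the scatter)) and compound 2 furthest away (a 190-fold lower number from compound 2 to compound 3 (2.29 log units; beyond the scatter)). Compound 4, `C[C@H](NC(=O)c1cc(C(F)(F)F)nn1C)c1nc(-c2ccnc(N3CCCC3)c2)no1`, differs from compound 3 in one place: pyrrolidin-1-yl in place of methoxy on an aromatic carbon. Within the data shown here, the steps that bear on this change are those at the same carbon: from hydrogen to methyl (a 32-fold higher number from compound 1 to compound 2 (1.50 log units; beyond the scatter) read backwards), from methyl to methoxy (a 6.1-fold lower number from compound 1 to compound 3 (0.79 log units; beyond the scatter)) and from hydrogen to methoxy (a 190-fold lower number from compound 2 to compound 3 (2.29 log units; beyond the scatter)). Each of them shows that a group on this carbon next to the ring nitrogen goes with a lower number, and the larger of the two measured groups gave the lower number. Pyrrolidin-1-yl is larger still, but no measured compound shows how far this trend carries, so compound 4 is expected to stay close to compound 3, with the step of a 1.7-fold higher number from compound 3 to compound 4 (0.22 log units; within the scatter) expected to fall within the scatter. Compound 4 is therefore estimated at 45 nM, in a range from 10 nM to 250 nM.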

Compound 4, half-maximal inhibitory concentration: 573 nM
Compound 4: the middle estimate sits 13-fold (1.10 log units) below what was measured; measured number above the stated range.
By their numbers in this assay, from the lowest: compound 3; then compound 1; then compound 4; then compound 2.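

In this assay, pyrrolidin-1-yl ends the run in which a larger group on this carbon went with a lower number, as it stands behind methoxy (a 21-fold higher number from compound 3 to compound 4 (1.33 log units; beyond the scatter)) and also behind methyl (a 3.5-fold higher number from compound 1 to compound 4 (0.54 log units; beyond the scatter)). A group here still beats hydrogen, though by less than methoxy does (a 9.2-fold lower number from compound 2 to compound 4 (0.96 log units; beyond the scatter)). Size alone therefore does not order the four compounds: hydrogen gives the highest number, pyrrolidin-1-yl the second highest, and methoxy the lowest.

The compounds shown leave open whether the loss goes with the ring of pyrrolidin-1-yl or with the nitrogen attached to the aromatic carbon, a question that dimethylamino and ethoxy groups on this carbon could help to separate. Nothing available gives a reason for this reversal.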